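Hydroxy for propanoyl on the shared core

A few compounds are considered here, and "the series" means these few. Any claim that something is new, unique, unknown or untested is made for them only; others in the source may bear on it.

Compound 1 `CCC(=O)c1ccc2c(c1)C(n1ccccc1=O)=CC(C)(C)O2` sits at the low end of the three numbers in hand: in a functional assay (trachea) with Rattus norvegicus as the target (a lower number here means a less potent compound, a higher number a more potent compound, by a factor of ten per unit of this negative logarithm), compound 1 gives 5.85. Compound 2 `CC1(C)C=C(n2ccccc2=O)c2cc(C(=O)c3ccco3)ccc2O1` gives 5.92, and compound 3 `CC1(C)C=C(n2ccccc2=O)c2cc(C(=O)c3ccccc3F)ccc2O1` gives 6.34. The steps measured so far all change the group on the carbonyl carbon: a number 0.07 log units higher from compound 1 to compound 2 (within the scatter), a number 0.49 log units higher from compound 1 to compound 3 (beyond the scatter) and a number 0.42 log units higher from compound 2 to compound 3 (beyond the scatter). Going by the values given here, compound 4 `CC1(C)C=C(n2ccccc2=O)c2cc(O)ccc2O1` differs from compound 1 in another way, (hydroxy in place of propanoyl on an aromatic carbon), so the carbonyl itself leaves and no measured step covers that kind of change. Among the compounds with values here, the measured steps show only that altering the group on the carbonyl carbon moves this assay by modest amounts at most. With the propanoyl gone, a step of uncertain size is expected, more likely downward than upward, and the range is set wide for that reason. Compound 4 is expected to give 5.2, between 4.5 and 5.9, which would mean an expected step of a number 0.65 log units lower from compound 1 to compound 4 (beyond the scatter).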

Compound 4, logarithm of the reciprocal of the active concentration, log(1/C): 5.31
Beside the measured number, compound 4's estimate is 0.11 log units below it, and the stated range covers the measured number.
By their numbers in this assay, from the lowest: compound 4; then compounds 1 and 2 (each within the scatter of the next); then compound 3.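

Replacing the whole acyl group with hydroxy on this aromatic carbon lowers the number in this assay beyond the scatter in all three available comparisons: a number 0.54 log units lower from compound 1 to compound 4 (beyond the scatter), a number 0.61 log units lower from compound 2 to compound 4 (beyond the scatter) and a number 1.03 log units lower from compound 3 to compound 4 (beyond the scatter). Going by these compounds alone, the earlier compounds all kept the carbonyl and changed only the group on its carbon, so these steps are the first to show that the position also tolerates losing the carbonyl only at a cost, with the largest step starting from the (2-fluorophenyl)carbonyl compound. Nothing at hand explains these drops.

The hydroxy result does not separate the departure of the carbonyl from the arrival of a hydrogen-bond donor; methoxy or an amine on this aromatic carbon would bear on that question. From the compounds shown here alone, whether a non-carbonyl group such as a nitrile could hold the number near that of the acyl compounds also remains open.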